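The source may hold more compounds than are shown below. What is called first, only, known or untested is meant among the compounds shown, and "the series" means these compounds.

In a functional assay on CEM-SS cells (Homo sapiens) for cytotoxicity (on this read-out higher numbers stand for weaker inhibition and lower numbers for stronger inhibition), compound 1 (`Nc1nc2cc(Cl)c(Cl)cc2n1Cc1ccc(Cl)cc1`) gives 32000 nM. Compound 2 (`CC(C)(C)c1ccc(Cn2c(N)nc3cc(Cl)c(Cl)cc32)cc1`) gives 27000 nM, which lies within the scatter of the value for compound 1, so the numbers place neither compound ahead of the other. Compound 3 (`Clc1ccc(Cn2c(Cl)nc3cc(Cl)c(Cl)cc32)cc1`) departs from compound 1 at a single place, with chloro in place of amino on an aromatic carbon. This carbon belongs to a five-membered aromatic ring with 2 nitrogen, part of a fused or bridged system of two rings, and it lies between two ring nitrogen atoms. Among the measured compounds shown here, the only measured step is a 1.2-fold lower number from compound 1 to compound 2 (0.07 log units; within the scatter), which replaces chloro with tert-butyl and leaves the amino group untouched. For the measured compounds named here, it therefore bears on the new change only indirectly, and no measured pair tests the loss of amino. On that thin evidence, no step beyond the scatter is expected in this assay, although the uncertainty is wide. The expected change is a 1.1-fold lower number from compound 1 to compound 3 (0.03 log units; within the scatter). The estimated value for compound 3 is 30000 nM, with an expected range from 10000 nM to 90000 nM.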

Compound 3, half-maximal inhibitory concentration: > 100000 nM
Compound 3 ended at the assay's limit; the forecaster's own chance of this, stated with the estimate: 25%; middle value at least 3.3-fold (0.52 log units) from the limit.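

In this assay, among the compounds shown here, the carbon between two ring nitrogen atoms proves sensitive to substitution, which the earlier compounds could not show, as their only step left the amino group untouched and stayed within the scatter. Putting chloro in place of amino at this carbon gives an at least 3.1-fold higher number from compound 1 to compound 3 (0.49 log units; beyond the scatter), so on this read-out the inhibition weakens, and this is the first change among the compounds shown to move the number beyond the scatter. For compound 3, > 100000 nM is a limit of the assay and not a number, so the step gives only a lower bound on the size of the change, and compound 3 sits at the edge of what the read-out can report: the limit of > 100000 nM in this assay, at which 1 of the 3 values shown sits.

The compounds shown do not separate the loss of the amino group from the arrival of chloro, and a hydrogen atom, a methyl group, a hydroxyl group or a methylamino group on this carbon would help tell those two apart. Going by these compounds, how far compound 3 lies past the limit stays open, as does whether the same change would have a similar effect with tert-butyl in place of the chloro of the benzyl ring.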